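Replacing the anilino group with piperidine on the shared core

The source may hold more compounds than are shown below. What is called first, only, known or untested is meant among the compounds shown, and "the series" means these compounds.

Of the compounds shown here, three sharing one core have been measured in a functional assay on MGC-803 cells (Homo sapiens) for inhibition, read by sulforhodamine B assay; on this read-out higher numbers stand for weaker inhibition and lower numbers for stronger inhibition. Compound 1 `COc1cccc(NC2=CC(=O)c3c(nc4n3[C@H]3OC[C@@H](O)[C@H]3OC4)C2=O)c1` gives 1790 nM, compound 2 `O=C1C(Nc2cccc(Cl)c2)=CC(=O)c2c1nc1n2[C@H]2OC[C@@H](O)[C@H]2OC1` gives 1530 nM, and compound 3 `COc1ccc(NC2=CC(=O)c3c(nc4n3[C@H]3OC[C@@H](O)[C@H]3OC4)C2=O)cc1` gives 2150 nM. Compound 3 carries the highest of the three numbers, yet its gaps to the others are small: a 1.2-fold higher number from compound 1 to compound 3 (0.08 log units; within the scatter) and a 1.4-fold higher number from compound 2 to compound 3 (0.15 log units; within the scatter), both within the scatter, as is a 1.2-fold lower number from compound 1 to compound 2 (0.07 log units; within the scatter).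

Compound 4 `O=C1C(N2CCCCC2)=CC(=O)c2c1nc1n2[C@H]2OC[C@@H](O)[C@H]2OC1` departs from compound 3 by a change of a different kind: piperidin-1-yl in place of (4-methoxyphenyl)amino on a double-bonded ring carbon. The three measured steps all exchange one substituted phenyl for another on the amine nitrogen, or swap a chloro for a methoxy on that ring, and every one of them stayed within the scatter. Among the compounds with values here, none replaces the (4-methoxyphenyl)amino group with a saturated ring lacking a hydrogen-bond donor, so no measured step bears directly on this change, and the expectation rests on the narrow spread of the known values alone.

Compound 4 is therefore expected to give about 3200 nM in this assay, within a wide range from 1000 nM to 12000 nM, corresponding to an estimated step of a 1.5-fold higher number from compound 3 to compound 4 (0.17 log units; within the scatter).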

Compound 4, half-maximal inhibitory concentration: > 4000 nM
Compound 4 was reported as a limit; the forecaster's own chance of this, stated with the estimate: 10%; middle value at least 1.2-fold (0.09 log units) away from the limit.
By their numbers in this assay, from the lowest: compounds 2, 1 and 3 (each within the scatter of the next). At a limit, above all of these: compound 4.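

In this assay compound 4 is reported only as a limit, > 4000 nM. Exchanging one substituted phenyl for another on the amine nitrogen had stayed within the scatter, but replacing the whole arylamino group with piperidin-1-yl on this double-bonded ring carbon gives steps beyond it: an at least 2.6-fold higher number from compound 2 to compound 4 (0.41 log units; beyond the scatter) and an at least 2.2-fold higher number from compound 1 to compound 4 (0.34 log units; beyond the scatter). Within the data shown here, the third comparison is less firm, with an at least 1.8-fold higher number from compound 3 to compound 4 (0.26 log units; that floor lies within the scatter), so only two of the three comparisons show that this change weakens inhibition.

The change removes both the aromatic ring and the amine hydrogen, and the compounds shown do not separate the two. Going by these compounds, a cyclohexylamino group, which keeps the amine hydrogen on a saturated ring, would bear on that question, and the size of the full step stays unknown behind the limit.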